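The compounds below may be only part of what the source reports. "The series", "measured", "known", "first", "only" and "open" are said of these compounds alone.

Measured compounds in an ADME assay on Vero cells (Chlorocebus sabaeus) for cytotoxicity, read by MTT assay, with a stated time of 72 h; a lower number here means a stronger inhibitor, a higher number a weaker inhibitor:
Compound 1 `CCCCc1nc(Cl)c(C2NC(=O)NC(C)=C2C(=O)Nc2cccc(C)c2)[nH]1`: "not determined" (no result reported).
Compound 2 `CCCCc1nc(Cl)c(C2NC(=O)NC(C)=C2C(=O)Nc2ccc(F)cc2)[nH]1`: compound 2 gives > 10 ug/mL, which is a limit of this assay and not a number.
Compound 3 `CCCCc1nc(Cl)c(C2NC(=O)NC(C)=C2C(=O)Nc2ccccc2[N+](=O)[O-])[nH]1`: "not determined" (no result reported).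

Compound 3 therefore stands without a number in this assay; the only figure shown in the whole set is the limit (the limit of > 10 ug/mL in this assay, at which 1 of the 3 values shown sits), and two entries carry no result at all. Compound 4 `CCCCc1nc(Cl)c(C2NC(=O)NC(C)=C2C(=O)Nc2ccc([N+](=O)[O-])cc2)[nH]1` has not been measured. It differs from compound 3 by 4-nitrophenyl in place of 2-nitrophenyl on an amide-type nitrogen. No measured step is shown for this change, so no size or direction of step can be taken from the data; no shift beyond the scatter is assumed. Among the measured compounds shown here, on the single limit seen for compound 2, compound 4 is estimated at 15 ug/mL, within 5 ug/mL to 50 ug/mL, with a fair chance that this assay again reports only a limit.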

Compound 4, half-maximal inhibitory concentration: > 10 ug/mL
Compound 4: a limit, no number (the forecaster's own chance of this, stated with the estimate: 70%); the middle value lies beyond the limit too.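

Compound 2 and compound 4 both stop at a limit and not a number, so no step can be read between them: the limit of > 10 ug/mL in this assay, at which 2 of the 4 values shown sit.

The compounds shown leave open how far beyond that limit either compound lies in this assay.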